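This account rests on a few compounds, and the source may have more. Where it says the series, first, only, none or still open, it means among the compounds named here.

Three compounds share one core and differ only in a single group on one aromatic carbon. Compound 1 `COc1cc(-n2cnc3ccc(-c4ccc(Cl)cc4)cc32)cc(OC)c1OC` carries a chloro there, compound 2 `COc1ccc(-c2ccc3ncn(-c4cc(OC)c(OC)c(OC)c4)c3c2)cc1` a methoxy, and compound 3 `COc1cc(-n2cnc3ccc(-c4ccc(C(C)=O)cc4)cc32)cc(OC)c1OC` an acetyl. In a functional assay on MCF7 cells (Homo sapiens) for antiproliferative activity, read by MTT assay, with a stated time of 72 h (on this read-out lower numbers stand for stronger inhibition and higher numbers for weaker inhibition), compound 1 gives 1320 nM. Compound 2 gives 210 nM and compound 3 gives 1540 nM. Among these three numbers compound 1 stands second highest: the step of a 6.3-fold lower number from compound 1 to compound 2 (0.80 log units; beyond the scatter) lies beyond the scatter, while the step of a 1.2-fold higher number from compound 1 to compound 3 (0.07 log units; within the scatter) lies within it, so compound 1 and compound 3 cannot be told apart on this read-out. The step of a 7.3-fold higher number from compound 2 to compound 3 (0.87 log units; beyond the scatter) shows the same gap from the other side.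

Compound 4 `COc1cc(-n2cnc3ccc(-c4ccc(C)cc4)cc32)cc(OC)c1OC` is the next member. Its difference from compound 1 is methyl in place of chloro on an aromatic carbon. Going by the values given here, no measured step swaps chloro for methyl, so the two steps out of compound 1 are the only guide: the exchange for methoxy gave a step beyond the scatter, the exchange for acetyl a step within it. Methyl is a different group from both, and no step beyond the scatter in either direction is expected here. Compound 4 is estimated to give 1200 nM, with a range from 400 nM to 3500 nM. The step of a 1.1-fold lower number from compound 1 to compound 4 (0.04 log units; within the scatter) is the expected outcome.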

Compound 4, half-maximal inhibitory concentration: 110 nM
Estimate against measurement, compound 4: 11-fold (1.04 log units) above; measured number outside the range, below it.
By their numbers in this assay, from the lowest: compounds 4 and 2 (each within the scatter of the next); then compounds 1 and 3 (each within the scatter of the next).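

In this assay, methyl gives a 12-fold lower number from compound 1 to compound 4 (1.08 log units; beyond the scatter) and a 14-fold lower number from compound 3 to compound 4 (1.15 log units; beyond the scatter), the two largest steps among these compounds. Exchanging chloro for methyl keeps the count at 1 heavy atom, so this count alone does not sort the groups at this position, on an aromatic carbon para to a large group. Methoxy no longer stands apart either: a 1.9-fold lower number from compound 2 to compound 4 (0.28 log units; within the scatter) lies within the scatter, so compound 2 and compound 4 cannot be told apart, and the four compounds fall into two pairs, with methyl and methoxy at the low numbers and chloro and acetyl at the high numbers.

No measurement shown here explains why the groups divide in this way. On these data alone, it remains open which pair other groups would join, such as fluoro, ethyl or an amine on the same carbon, and whether a longer chain like ethoxy would stay with methoxy and methyl or move towards the higher numbers of chloro and acetyl.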